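The source may report more compounds than this note shows. Statements on the series, on what has been measured and on what is new or still open speak of the compounds shown alone.

Measured so far:
compound 1 `CCCNc1nc(-c2ccccc2)nc2c1nnn2Cc1ccccc1F` — in an assay on Cerebral cortex for displacement of a labelled ligand from adenosine receptor A1 (Bos taurus) (a higher number here means a weaker inhibitor, a lower number a stronger inhibitor), compound 1 gives 3.2 nM
compound 2 `CCCCNc1nc(-c2ccccc2)nc2c1nnn2Cc1ccccc1` — in this assay compound 2 gives 11 nM

Compound 2 stands at the higher of the two numbers; compound 1 lies well below it, beyond the scatter, but the two differ in more than one place, so no single step can be read from them. Compound 3 `CCCCNc1nc(-c2ccccc2)nc2c1nnn2Cc1ccccc1F` differs from compound 2 by fluoro in place of hydrogen on an aromatic carbon. With no measured step of this kind in hand, a modest drop in the number is expected, estimated as a 1.8-fold lower number from compound 2 to compound 3 (0.26 log units; within the scatter). Compound 3 is therefore expected near 6 nM, within 2.5 nM to 15 nM.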

Compound 3, inhibition constant: 4.3 nM
Compound 3: the middle estimate sits 1.4-fold (0.14 log units) above what was measured; the range from low to high includes it.
By their numbers in this assay, from the lowest: compounds 1 and 3 (each within the scatter of the next); then compound 2.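

In this assay, for the compounds shown here, fluoro in place of hydrogen on the benzyl group gives a 2.6-fold lower number from compound 2 to compound 3 (0.41 log units; beyond the scatter) and so gives the first single-place reading at this position, a modest step beyond the scatter. With the 2-fluorobenzyl group held fixed, methyl in place of hydrogen on the saturated chain gives a 1.3-fold higher number from compound 1 to compound 3 (0.13 log units; within the scatter) within the scatter, so this chain change shows no readable difference. No supporting measurement explains either step. Open, on these data alone, is whether chloro or methoxy in place of fluoro would keep this step. Also open, as far as these compounds go, is how a longer chain such as pentyl would read.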